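Shortening the amine-bearing chain: from compound 2 to compound 4

The source may report more compounds than this note shows. Statements on the series, on what has been measured and on what is new or still open speak of the compounds shown alone.

Measured compounds:
compound 1 `CN(C)CCCNc1nc(-c2ccc(NC(=O)Nc3ccccc3Cl)cc2)nc2c(Cl)c(Cl)sc12`: 1560 nM
compound 2 `CCN(CC)CCCNc1nc(-c2ccc(NC(=O)Nc3ccccc3Cl)cc2)nc2c(Cl)c(Cl)sc12`: 970 nM
compound 3 `CCN(CC)CCCNc1nc(-c2ccc(NC(=O)Nc3ccc(C)cc3)cc2)nc2c(Cl)c(Cl)sc12`: 3040 nM

In a functional assay on MDA-MB-231 cells (Homo sapiens) for cytotoxicity, read by MTT assay, with a stated time of 72 h (on this read-out lower numbers stand for stronger inhibition and higher numbers for weaker inhibition), compound 2 gives 970 nM, the lowest of the three numbers. The step of a 1.6-fold lower number from compound 1 to compound 2 (0.21 log units; within the scatter) is within the scatter, while a 3.1-fold higher number from compound 2 to compound 3 (0.50 log units; beyond the scatter) is a modest change. Compound 4 (`CCN(CC)CCNc1nc(-c2ccc(NC(=O)Nc3ccccc3Cl)cc2)nc2c(Cl)c(Cl)sc12`) has not been measured in this assay; it differs from compound 2 by diethylamino in place of (diethylamino)methyl on a saturated chain carbon, two bonds along the chain from a nitrogen on an aromatic ring, a shortening of the chain. Within the data shown here, none of the measured steps alters this chain's length; the nearest, a 1.6-fold lower number from compound 1 to compound 2 (0.21 log units; within the scatter), changes only the amine at its end and was within the scatter. Among the measured compounds shown here, no step is therefore expected beyond the scatter, and compound 4 is estimated at 1100 nM (range 450 nM to 2700 nM), a step of a 1.1-fold higher number from compound 2 to compound 4 (0.05 log units; within the scatter).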

Compound 4, half-maximal inhibitory concentration: 1410 nM
For compound 4 the middle estimate is 1.3-fold (0.11 log units) below the measured one; measured number inside the range.
By their numbers in this assay, from the lowest: compounds 2, 4, 1 and 3 (each within the scatter of the next, the first and the last beyond it).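

Replacing 3-(diethylamino)propyl with 2-(diethylamino)ethyl is the first change shown in the length of this chain, and in this assay it gives a 1.5-fold higher number from compound 2 to compound 4 (0.16 log units; within the scatter). Shortening the chain and exchanging its terminal amine together give a 1.1-fold lower number from compound 1 to compound 4 (0.04 log units; within the scatter), so neither step separates these compounds beyond the scatter. No evidence is available to explain this result.

The compounds shown leave open how a longer chain, or a chain ending in a carboxylic acid, would behave. Whether the step to 4-methylphenyl on the amide-type nitrogen would carry over to the shorter chain also remains unresolved.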